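Methoxy placement on the arylthioether acetamide series

The source may hold more compounds than are shown below. What is called first, only, known or untested is meant among the compounds shown, and "the series" means these compounds.

Among the measured compounds shown here, compound 3 `CC(=O)NCCSc1ccccc1` gives 339 nM in an assay on NIH3T3 cells for displacement of a labelled ligand from melatonin receptor type 1B (Homo sapiens), with a stated time of 90 min (on this read-out lower numbers stand for stronger inhibition and higher numbers for weaker inhibition), and stands second highest of the three numbers measured so far. Compound 2 `COc1cccc(SCCNC(C)=O)c1` gives 39.8 nM in this assay, and compound 1 `COc1ccccc1OC(C)CNC(C)=O` gives 5130 nM. For the measured compounds named here, the only one-place step on record runs an 8.5-fold higher number from compound 2 to compound 3 (0.93 log units; beyond the scatter), which shows that taking the methoxy off an aromatic carbon of this ring weakens binding clearly. Compound 4 `COc1ccc(SCCNC(C)=O)cc1` is not yet measured; it differs from compound 3 in methoxy in place of hydrogen on an aromatic carbon. The step from compound 2 to compound 3 is the one that bears on this change: it concerns the same group on the same ring, but in the reverse direction and at a different place on the ring, so its full size need not carry over. The expectation for this assay is therefore a lower number for compound 4 than for compound 3, by roughly a 3.1-fold lower number from compound 3 to compound 4 (0.49 log units; beyond the scatter), beyond the scatter yet likely short of what compound 2 shows. The estimated value for compound 4 is 110 nM, with a range from 30 nM to 400 nM.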

Compound 4, inhibition constant: 2400 nM
The estimate for compound 4 lay 22-fold (1.34 log units) below the measured number; measured number above the stated range.
By their numbers in this assay, from the lowest: compound 2; then compound 3; then compound 4; then compound 1.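

In this assay, methoxy in place of hydrogen on an aromatic carbon, para to a group of 7 heavy atoms, gives no gain over hydrogen: this change produces a 7.1-fold higher number from compound 3 to compound 4 (0.85 log units; beyond the scatter) and leaves compound 4 on the weak side of compound 3. The earlier step, an 8.5-fold higher number from compound 2 to compound 3 (0.93 log units; beyond the scatter), showed only that the loss of a methoxy from another place on the ring goes with a higher number, so the direction of this change is now seen to differ with its place among these compounds. The two methoxy isomers carry the same group on the same core, yet compound 2 reads 39.8 nM and compound 4 reads 2400 nM. Nothing in the data on hand accounts for this difference between the two placements.

Going by these compounds, whether a hydroxyl group or a chlorine atom at the place held by the methoxy of compound 4 would follow the same course remains open. Also open, on these data alone, is whether an ethoxy group there would shift the number further from that of compound 3, and how the chain carrying the acetamide contributes to any of these steps.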